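The source may hold more compounds than are shown below. What is called first, only, known or untested is meant among the compounds shown, and "the series" means these compounds.

Measured in a functional assay on K562/Adr cells (Homo sapiens) for cytotoxicity, read by sulforhodamine B assay, with a stated time of 48 h; on this read-out higher numbers stand for weaker inhibition and lower numbers for stronger inhibition:
- compound 1 `CCN(CC)CCCn1c(=O)/c(=C/c2cc(OC)c(OC)c(OC)c2)s/c1=C1/C(=O)Nc2ccc(C)cc21`: 2020 nM
- compound 2 `CCN(CC)CCCn1c(=O)/c(=C/c2ccc(O)cc2)s/c1=C1/C(=O)Nc2ccc(Cl)cc21`: 48800 nM
- compound 3 `CCN(CC)CCCn1c(=O)/c(=C/c2ccc(F)cc2F)s/c1=C1/C(=O)Nc2cc(F)ccc21`: 4120 nM

Compound 1 gives the lowest number of the three at 2020 nM. Compound 3 is its nearest neighbour, with a higher number that lies just beyond the scatter. Compound 2 is furthest away, with a much higher number that also lies beyond the scatter. These three compounds differ in several places at once, so no single structural change can be read from their values.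

The next compound to be tested is compound 4 `CCN(CC)CCCn1c(=O)/c(=C/c2cc(OC)c(OC)c(OC)c2)s/c1=C1\C(=O)Nc2ccc(C)cc21`. Its difference from compound 1 is as follows: the two compounds have the same atoms and bonds and differ only in configuration as drawn: 1 of 2 stereo elements differ; a double bond is drawn E in compound 1 and Z in compound 4. Among the measured compounds shown here, no measured pair in this set shows what a change of configuration at a double bond does in this assay. The expectation therefore starts from compound 1 at 2020 nM, and the range is kept wide to allow for that gap in the data. The expected change is small, with no shift beyond the scatter and at most a slight lean towards a higher number. The expected step is a 1.3-fold higher number from compound 1 to compound 4 (0.11 log units; within the scatter). For compound 4 the estimated value is 2600 nM, with an expected range of 900 nM to 7500 nM.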

Compound 4, half-maximal inhibitory concentration: 2020 nM
For compound 4 the middle estimate is 1.3-fold (0.11 log units) above the measured one; low and high end bracket the measured number.
By their numbers in this assay, from the lowest: compounds 1 and 4 (each within the scatter of the next); then compound 3; then compound 2.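

In this assay, among the compounds shown here, the only pair so far that isolates one structural feature gives no change at the digits printed from compound 1 to compound 4 (within the scatter), so the two drawn forms cannot be told apart on this read-out. The earlier compounds shown here could not show this, as each differed from the others in several places at once, whereas this pair leaves the substituents untouched and tests a double bond drawn E against one drawn Z: the fact that compounds 1 and 4 differ only in the configuration as drawn. For the trimethoxy-substituted, methyl-bearing member of the series, configuration as drawn at this double bond therefore gives no separation in potency, and the differences among compounds 1, 2 and 3 remain unassigned to any single structural feature.

This single pair leaves open whether the same insensitivity to the drawn configuration holds with other substituents, such as the chlorine and hydroxyl of compound 2 or the fluorines of compound 3. Also open, on these data alone, is how the read-out responds when the diethylamine end gives way to a morpholine or the propyl link to a longer chain, or when a carboxylic acid or nitrile replaces the methoxy groups.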